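A few compounds are considered here, and "the series" means these few. Any claim that something is new, unique, unknown or untested is made for them only; others in the source may bear on it.

Measured in an ADME assay on HCT-116 cells (Homo sapiens) for cytotoxicity, read by CellTiter-Glo, with a stated time of 72 h; on this read-out higher numbers stand for weaker inhibition and lower numbers for stronger inhibition:
- compound 1 `CC1CCN(C2CCN(S(=O)(=O)c3ccc(C#N)cc3)CC2)CC1`: > 5000 nM (a limit)
- compound 2 `CCc1cc(Br)ccc1S(=O)(=O)N1CCC(N2CCC(C)CC2)CC1`: > 5000 nM (a limit)

Compound 1 has no numerical value, only the limit > 5000 nM. Compound 2 likewise has only a limit, > 5000 nM. Among the compounds with values here, the series so far therefore amounts to the limit of > 5000 nM in this assay, at which 2 of the 2 values shown sit, and no measured step is available to size a structural change.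

The next compound is compound 3 `CC1CCN(C2CCN(S(=O)(=O)c3ccccc3Br)CC2)CC1`, with 2-bromophenyl in place of 4-cyanophenyl on a sulfonyl sulfur. In this assay, no step beyond the scatter is expected, in either direction, and this expectation rests only on (the limit of > 5000 nM in this assay, at which 2 of the 2 values shown sit). The estimated step is a step that the limit leaves unreadable from compound 1 to compound 3. Compound 3 is expected at 6000 nM. The estimated range for compound 3 runs from 2500 nM to 10000 nM, and a reading at the limit is the likeliest outcome.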

Compound 3, half-maximal inhibitory concentration: > 5000 nM
Compound 3: no number, only a limit; the forecaster's own chance of this, stated with the estimate: 85%; the middle value lies beyond the limit too.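

Within the data shown here, compound 1 and compound 3 both stand only as limits in this assay, so no step between them can be read. The compounds shown leave open whether 2-bromophenyl or 4-cyanophenyl on the sulfonyl sulfur makes any difference, as all readings sit at one limit: the limit of > 5000 nM in this assay, at which 3 of the 3 values shown sit.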